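Swapping the oxetane side chain of compound 1

A few compounds are considered here, and "the series" means these few. Any claim that something is new, unique, unknown or untested is made for them only; others in the source may bear on it.

Compound 1 `Cc1ccc2nc(N3CCCc4ccc(F)cc4C3)cc(NCC3(N)COC3)c2c1` was tested in an ADME assay on HEp-2 cells (Homo sapiens) for cytotoxicity, read by CCK-8 assay, with a stated time of 5 days; on this read-out higher numbers stand for lower toxicity in this test and lower numbers for higher toxicity in this test. In this test compound 1 gives > 100000 nM, which is a limit of the assay rather than a number. Two further compounds share the core. Compound 2 `NCCNc1cc(N2CCCc3ccccc3C2)nc2ccccc12` gives 23000 nM, and compound 3 `NCCNc1cc(N2CCCc3ccccc3C2)nc2c(Cl)cccc12` gives 25000 nM. For the measured compounds named here, the one step that can be read between them, a 1.1-fold higher number from compound 2 to compound 3 (0.04 log units; within the scatter), shows that a chloro in place of hydrogen on an aromatic carbon leaves the number where it was.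

Compound 4 `Cc1ccc2nc(N3CCCc4ccc(F)cc4C3)cc(NCCNC3COC3)c2c1` differs from compound 1 in the side chain: ((oxetan-3-yl)amino)methyl in place of 3-aminooxetan-3-yl on a saturated chain carbon bound to a nitrogen on an aromatic ring. Going by the values given here, no measured step covers a change of this kind, so the step from compound 2 to compound 3 bears on it only as a sign that small changes around this core have so far moved the number little. Compound 1 itself sits at the limit of > 100000 nM in this assay, at which 1 of the 3 values shown sits, so there is no number to move from, only a floor. The expectation for compound 4 is therefore a step of a number no higher from compound 1 to compound 4 (the limit leaves the size open), that is, no step beyond the scatter. Compound 4 is estimated at 100000 nM, with a range from 30000 nM to 300000 nM, and the most likely outcome is that the assay again reports only a limit.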

Compound 4, half-maximal cytotoxic concentration: > 100000 nM
Compound 4: a limit, no number; the forecaster's own chance of this, stated with the estimate: 65%; the middle value lies on the limit itself.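

Compound 1 and compound 4 both end at a limit of the assay, not a number, so no step between them can be read: the limit of > 100000 nM in this assay, at which 2 of the 4 values shown sit.

The compounds shown leave open how far, if at all, ((oxetan-3-yl)amino)methyl in place of 3-aminooxetan-3-yl moves the number in this assay.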